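The source may report more compounds than this note shows. Statements on the series, on what has been measured and on what is new or still open speak of the compounds shown alone.

Measured compounds:
Compound 1 `C=Cc1cccc(-c2[nH]c3cc(OC)ccc3c(=O)c2C(=O)OCC)c1` in an ADME assay on Raji cells (Homo sapiens) for cytotoxicity, read by luminescence, with a stated time of 72 h (a higher number here means that more compound is needed for the effect, a lower number that less compound is needed), gives > 21500 nM, which is a limit of the assay rather than a number.
Compound 2 `CCOC(=O)c1c(-c2cccc(-c3ccccc3)c2)[nH]c2cc(OC)ccc2c1=O` in this assay gives > 21500 nM, again a limit.
Compound 3 `CCOC(=O)c1c(-c2cccc([N+](=O)[O-])c2)[nH]c2cc(OC)ccc2c1=O` in this assay gives > 21500 nM, also a limit.

Compound 2 therefore stands at the limit of this assay, and the two further values shown are limits as well, so no number places it above or below its neighbours. The step from compound 2 to the unmeasured compound 4 `CCOC(=O)c1c(-c2cccc(O)c2)[nH]c2cc(OC)ccc2c1=O` is hydroxy in place of phenyl on an aromatic carbon.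

Three measured steps change the same aromatic carbon and so bear on this change: a step that the two limits leave unreadable from compound 1 to compound 2, a step that the two limits leave unreadable from compound 1 to compound 3 and a step that the two limits leave unreadable from compound 2 to compound 3. None of them has a readable size, because of the limit of > 21500 nM in this assay, at which 3 of the 3 values shown sit. Replacing vinyl by phenyl, vinyl by nitro, or phenyl by nitro at that carbon left every compound at the limit, so these steps give no direction and no size to carry over to the hydroxy group. Among the compounds with values here, nothing among the measured compounds suggests a step beyond the scatter in either direction.

Compound 4 is therefore expected to sit at the limit as well, the expected step being a number no higher from compound 2 to compound 4 (the limit leaves the size open). The estimate for compound 4 in this assay is 21500 nM, with a range from 8000 nM to 60000 nM.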

Compound 4, half-maximal effective concentration: > 21500 nM
Compound 4: a limit, no number (the forecaster's own chance of this, stated with the estimate: 85%); the middle value sits exactly at the limit.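

In this assay compound 4 gives > 21500 nM, a limit of the assay and not a number. Within the data shown here, no step from compound 1, compound 2 or compound 3 to compound 4 can be read, because all four compounds share one limit: the limit of > 21500 nM in this assay, at which 4 of the 4 values shown sit. The compounds shown leave open what the actual half-maximal effective concentration of each compound is, and whether the groups compared at this aromatic carbon differ at all.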